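Allyl to Phenyl on a Saturated Ring Carbon

The compounds below may be only part of what the source reports. "The series", "measured", "known", "first", "only" and "open" are said of these compounds alone.

Among the measured compounds shown here, compound 1 `C=CCC1C(=C)C(=O)N(c2ccccc2)N1c1ccccc1` is the only member of this small set that comes with a number. In an ADME assay on HUVEC cells (Homo sapiens) for inhibition, read by MTT assay, with a stated time of 48 h (on this read-out lower numbers stand for stronger inhibition and higher numbers for weaker inhibition), compound 1 gives 2730 nM, and it stands alone there. Compound 2 `C=C1CN(C)N(c2ccc(Cl)cc2)C1=O` carries in this assay only the entry "not determined" (no result reported). Compound 3 `C=C1CN(C)N(c2ccccc2)C1=O` likewise carries in this assay only the entry "not determined" (no result reported). For the measured compounds named here, no step between two measured compounds therefore exists. Compound 4 `C=C1C(=O)N(c2ccccc2)N(c2ccccc2)C1c1ccccc1` differs from compound 1 by phenyl in place of allyl on a saturated ring carbon. With nothing measured to lean on, the account expects in this assay a step no larger than the usual scatter, at most a slight shift toward stronger inhibition, and the estimated step of a 1.4-fold lower number from compound 1 to compound 4 (0.14 log units; within the scatter) reflects that. Compound 4 is accordingly expected to give 2000 nM, within a range from 700 nM to 6000 nM.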

Compound 4, half-maximal inhibitory concentration: 4460 nM
For compound 4 the middle estimate is 2.2-fold (0.35 log units) below the measured one; low and high end bracket the measured number.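

Phenyl in place of allyl on the saturated ring carbon gives a 1.6-fold higher number from compound 1 to compound 4 (0.21 log units; within the scatter) in this assay and so shows that this position takes an aromatic ring without a step beyond the scatter. Going from 3 to 6 heavy atoms here thus leaves the two numbers indistinguishable in this read-out. No measurement in hand explains this result. From the compounds shown here alone, whether an amine, a carboxylic acid or a longer chain on this carbon would read the same stays open. So does whether a pyridine ring would match phenyl there.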